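A Side Chain Swap on a Flat Series

The source may report more compounds than this note shows. Statements on the series, on what has been measured and on what is new or still open speak of the compounds shown alone.

Compound 1 `COc1cccc2cc(-c3ccccc3)c(O)nc12` gives 10000 nM here
Compound 2 `COc1cc(OC)c2cc(-c3ccccc3)c(O)nc2c1` gives 10000 nM here
Compound 3 `COc1ccc(-c2cc3c(OC)cc(OC)cc3n(CC(=O)OCc3ccccc3)c2=O)cc1` gives 10000 nM here

Within the data shown here, these three readings come from a functional assay on MCF7 cells (Homo sapiens) for cytotoxicity, read by colorimetric assay and MTT assay (a lower number here means a stronger inhibitor, a higher number a weaker inhibitor), and they are the only numbers available. Compound 3 stands level with compounds 1 and 2 at the digits shown, so the set has no spread and no ranking can be drawn from it. The next compound to be tested is compound 4 `CCN(CC)C(=O)CCn1c(=O)c(-c2ccc(OC)cc2)cc2c(OC)cc(OC)cc21` and it departs from compound 3 by one change: (diethylcarbamoyl)methyl in place of benzyloxycarbonyl on a saturated chain carbon bound to an aromatic nitrogen on a saturated chain carbon bound to an aromatic nitrogen. Cut one bond further out, the same difference reads (benzyloxycarbonyl)methyl to 2-(diethylcarbamoyl)ethyl. Among the measured compounds shown here, no pair of measured compounds differs in one place only, so the data give no direct measure of what such a change does. The expectation therefore rests on compound 3 at 10000 nM in this series, along with the identical readings of its two neighbours. The expected step of a 1.1-fold lower number from compound 3 to compound 4 (0.05 log units; within the scatter) is estimated to stay within the usual scatter, with no firm direction. For compound 4 the estimated value is 9000 nM in this assay. The range expected for compound 4 runs from 2500 nM to 12000 nM in this assay.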

Compound 4, half-maximal inhibitory concentration: 10000 nM
The estimate for compound 4 lay 1.1-fold (0.05 log units) below the measured number; low and high end bracket the measured number.
By their numbers in this assay, from the lowest: compounds 1, 2, 3 and 4 (each within the scatter of the next).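

Putting (diethylcarbamoyl)methyl in place of benzyloxycarbonyl on a saturated chain carbon bound to an aromatic nitrogen gives no change at the digits printed from compound 3 to compound 4 (within the scatter) in this assay on the shared core. Among these compounds, this is the first pair in the set that differs in one place, so it gives the first direct reading of this position: a side chain with a six-membered aromatic ring and a ringless side chain ending in a diethyl amide read the same, and the pair gives no reason to rank one above the other. No measured evidence bears on why the two side chains read alike.

On these data alone, whether a carboxylic acid or an amine at the end of this chain, or a longer chain, would give a reading apart from this level remains open. No pair shown isolates the methoxy groups on the shared core, and what they contribute in this assay also remains an open question.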